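This account rests on a few compounds, and the source may have more. Where it says the series, first, only, none or still open, it means among the compounds named here.

Compound 3 `COc1ccc(-c2nn(-c3ccc(Cl)cc3)cc2C(CC(=O)c2ccc(Cl)cc2)C(=O)c2ccc(F)cc2)cc1` stands highest of the three measured compounds in a functional assay on the whole organism (strain Wistar albino) for inhibition, with Rattus norvegicus as the target, read by paw edema, with stated times of 1 h and 3 h, at a dose of 0.32 mmol/kg by the intraperitoneal route (a lower number here means less inhibition, a higher number more inhibition at the dose given (going by the name of the read-out)), where compound 3 gives 37.8%. Its nearest neighbour, compound 2 `COc1ccc(C(=O)C(CC(=O)c2ccc(Cl)cc2)c2cn(-c3ccc(Cl)cc3)nc2-c2ccc(C)cc2)cc1`, gives 23.9%, and compound 1 `Cc1ccc(-c2nn(-c3ccc(Cl)cc3)cc2C(CC(=O)c2ccc(Cl)cc2)C(=O)c2ccc(F)cc2)cc1` gives 19.4%. Compound 4 `COc1ccc(C(=O)C(CC(=O)c2ccc(Cl)cc2)c2cn(-c3ccc(Cl)cc3)nc2-c2ccc(OC)cc2)cc1` differs from compound 3 by methoxy in place of fluoro on an aromatic carbon. The same change has been measured once, as a number 4.5 percentage points higher from compound 1 to compound 2 (within the scatter), a step within the scatter. The other measured step, a number 18.4 percentage points higher from compound 1 to compound 3 (beyond the scatter), concerns methoxy in place of methyl and bears only indirectly. Among the compounds with values here, the one relevant step suggests that no change beyond the scatter is expected, with at most a slight rise. Compound 4 is therefore expected to give 41%, between 30% and 52%. The expected step is a number 3.2 percentage points higher from compound 3 to compound 4 (within the scatter).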

Compound 4, a percentage reported as inhibition, in the whole organism at one dose (the size of the read-out at that dose, not a potency): 9.61%
Compound 4: the middle estimate sits 31.4 percentage points above what was measured; measured number below the stated range.
By their numbers in this assay, from the lowest: compounds 4, 1 and 2 (each within the scatter of the next, the first and the last beyond it); then compound 3.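

In this assay, methoxy in place of fluoro gives a number 28.2 percentage points lower from compound 3 to compound 4 (beyond the scatter), so this change at the 4-position of the phenyl carbonyl is not neutral on every core, and its outcome depends on the core that carries it: the same change on two cores in this assay, a number 4.5 percentage points higher (within the scatter) from compound 1 to compound 2 and a number 28.2 percentage points lower (beyond the scatter) from compound 3 to compound 4, 32.7 percentage points apart, beyond the scatter of two such steps. Methoxy in place of methyl likewise changes direction, giving a number 14.3 percentage points lower from compound 2 to compound 4 (beyond the scatter) on the core with the 4-methoxyphenyl carbonyl: the same change on two cores in this assay, a number 18.4 percentage points higher (beyond the scatter) from compound 1 to compound 3 and a number 14.3 percentage points lower (beyond the scatter) from compound 2 to compound 4, 32.7 percentage points apart, beyond the scatter of two such steps. The two changes therefore do not act independently across these four compounds.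

Why they interact stays open. So does how a hydroxy group or a dimethylamino group on the same aromatic carbon would read.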